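Removing the vinyl group from compound 1

The source may report more compounds than this note shows. Statements on the series, on what has been measured and on what is new or still open speak of the compounds shown alone.

Measured in a functional assay on HT-29 cells (Homo sapiens) for inhibition, read by sulforhodamine B assay, with a stated time of 72 h; a lower number here means a stronger inhibitor, a higher number a weaker inhibitor:
compound 1 `C=CC1C(=O)N(c2cc(OC)c(OC)c(OC)c2)C1c1ccc(OC)cc1`: 10 nM
compound 2 `C=CC1C(=O)N(c2cc(OC)c(OC)c(OC)c2)C1c1ccc(SC)cc1`: 113 nM
compound 3 `C=CC1C(=O)N(c2cc(OC)c(OC)c(OC)c2)C1c1ccc(OCC)cc1`: 97 nM

Compound 1 gives the lowest number of the three in this assay. Its two neighbours are reached by changes at the aromatic carbon of the 4-methoxyphenyl group: an 11-fold higher number from compound 1 to compound 2 (1.05 log units; beyond the scatter) and a 9.7-fold higher number from compound 1 to compound 3 (0.99 log units; beyond the scatter), both beyond the scatter, while a 1.2-fold lower number from compound 2 to compound 3 (0.07 log units; within the scatter) stays within it.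

Compound 4 `COc1ccc(C2CC(=O)N2c2cc(OC)c(OC)c(OC)c2)cc1` is the next candidate. Relative to compound 1 the change is hydrogen in place of vinyl on a saturated ring carbon. For the measured compounds named here, none of the measured steps touches this saturated ring carbon; all three concern the aromatic substituent, so they do not bear on the change from compound 1 to compound 4 and offer no direct guide to its size or direction.

Without a comparable step in the series, the expectation for compound 4 is a weaker inhibitor than compound 1, with a wide range, which as a step is estimated at a 6.0-fold higher number from compound 1 to compound 4 (0.78 log units; beyond the scatter). The estimate for compound 4 in this assay is 60 nM, between 10 nM and 400 nM.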

Compound 4, half-maximal inhibitory concentration: 65 nM
Estimate against measurement, compound 4: 1.1-fold (0.03 log units) below; low and high end bracket the measured number.
By their numbers in this assay, from the lowest: compound 1; then compounds 4, 3 and 2 (each within the scatter of the next).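

In this assay, for the compounds shown here, a 6.5-fold higher number from compound 1 to compound 4 (0.81 log units; beyond the scatter) gives the first direct reading at this saturated ring carbon of the four-membered ring, where the earlier steps reached only the aromatic substituent. The step lies beyond the scatter, so vinyl counts for something at this carbon, yet compound 4 still gives 65 nM with hydrogen there, so the vinyl group is not required for nanomolar inhibition in this assay. Nothing available here accounts for the size of this step.

With only vinyl and hydrogen shown at this carbon, it remains open whether an ethyl group, which would keep both carbons without the double bond, would match vinyl, and how a hydroxyl or an amine would fare there. Also open, from the compounds shown here alone, is whether the step would be similar with the 4-ethoxyphenyl or 4-methylsulfanylphenyl group in place of the 4-methoxyphenyl group.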